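Piperidine to Methylpiperazine Swap in an Adenosine A3 Series

The source may report more compounds than this note shows. Statements on the series, on what has been measured and on what is new or still open speak of the compounds shown alone.

Measured compounds:
compound 1 `CN1CCN(c2nc(-c3ccc(Cl)c(Cl)c3)nc3[nH]cnc23)CC1` — > 80%
compound 2 `Clc1ccc(-c2nc(N3CCCCC3)c3nc[nH]c3n2)cc1Cl` — > 80%
compound 3 `Oc1cccc(-c2nc(N3CCCCC3)c3nc[nH]c3n2)c1` — > 80%

In an assay on cells for displacement of a labelled ligand from adenosine receptor A3 (Homo sapiens), read by scintillation counting and radioligand binding, with a stated time of 180 min, tested at 10 uM (a higher number here means more inhibition at the concentration tested (going by the name of the read-out), a lower number less inhibition), compound 1 gives > 80%, which is a limit of the assay and not a number. In this assay compound 2 likewise gives > 80%, also a limit. In this assay compound 3 gives > 80%, again a limit. The step that the two limits leave unreadable from compound 2 to compound 1 is therefore not readable in size, since (the limit of > 80% in this assay, at which 3 of the 3 values shown sit). How the core of compound 3 differs from that of compound 2 is not broken down here.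

Compound 4 `CN1CCN(c2nc(-c3cccc(O)c3)nc3[nH]cnc23)CC1` has not yet been measured. It differs from compound 3 by 4-methylpiperazin-1-yl in place of piperidin-1-yl on an aromatic carbon. Compound 1 differs from compound 2 by 4-methylpiperazin-1-yl in place of piperidin-1-yl on an aromatic carbon. These are the same kind of change, but the surroundings differ: in compound 3 the place is meta to a 3-hydroxyphenyl group (7 heavy atoms), whereas in compound 2 it is meta to a group of 8 heavy atoms.

For compound 4 the step that the limit leaves unreadable from compound 3 to compound 4 is expected to be small, resting on the step that the two limits leave unreadable from compound 2 to compound 1 and on (the limit of > 80% in this assay, at which 3 of the 3 values shown sit). Compound 4 is thus estimated at 88%, between 72% and 99%.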

Compound 4, a percentage reported as inhibition, at one concentration (the size of the read-out at that concentration, not a potency): > 80%
Compound 4 was reported as a limit; the forecaster's own chance of this, stated with the estimate: 80%; the middle value lies beyond the limit too.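

In this assay compound 4 gives > 80% as a limit of the assay and not a number. Going by these compounds alone, no step from compound 3 or compound 1 to compound 4 can be read in size, because the values do not separate: the limit of > 80% in this assay, at which 4 of the 4 values shown sit. In this assay the compounds shown leave open whether 4-methylpiperazin-1-yl for piperidin-1-yl, or 3-hydroxyphenyl for 3,4-dichlorophenyl, changes the inhibition at all.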